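A few compounds are considered here, and "the series" means these few. Any claim that something is new, unique, unknown or untested is made for them only; others in the source may bear on it.

Measured compounds:
compound 1, `CN1CCN(c2ccc(C3=NN(S(C)(=O)=O)C(c4ccc(N(C)C)cc4)C3)cc2)CC1` — 0.6%
compound 2, `CC(=O)N1N=C(c2ccc(-n3cncn3)cc2)CC1c1ccc(N(C)C)cc1` — 7.4%
compound 3, `CN(C)c1ccc(C2CC(c3ccc(-n4cncn4)cc3)=NN2S(C)(=O)=O)cc1` — 7.8%

In a functional assay on MDA-MB-231 cells (Homo sapiens) for inhibition, read by sulforhodamine B assay, tested at 10 uM (on this read-out higher numbers stand for more inhibition at the one concentration tested (going by the name of the read-out) and lower numbers for less inhibition), compound 3 gives 7.8%, the highest of the three numbers, yet its gaps to both others lie within the scatter: compound 2 gives 7.4% and compound 1 gives 0.6%. The two measured steps are small: a number 7.2 percentage points higher from compound 1 to compound 3 (within the scatter) and a number 0.4 percentage points higher from compound 2 to compound 3 (within the scatter). Compound 4, `CN(C)c1ccc(C2CC(c3ccc(-n4cncn4)cc3)=NN2S(=O)(=O)c2ccc(C(F)(F)F)cc2)cc1`, differs from compound 3 by 4-(trifluoromethyl)phenyl in place of methyl on a sulfonyl sulfur. For the measured compounds named here, no measured step changes the group on the sulfonyl sulfur, so none bears directly on this change; the nearest is the exchange of acetyl for methylsulfonyl on the ring nitrogen, which gave a number 0.4 percentage points higher from compound 2 to compound 3 (within the scatter), a difference within the scatter. All three measured values sit low and close together, so the expectation for compound 4 is no step beyond the scatter in this assay, with the estimated step being a number 2.2 percentage points higher from compound 3 to compound 4 (within the scatter). Compound 4 is therefore expected to give about 10% in this assay, within a range from 0% to 35%.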

Compound 4, a percentage reported as inhibition, at one concentration (the size of the read-out at that concentration, not a potency): 15.3%
Estimate against measurement, compound 4: 5.3 percentage points below; the measured number falls inside the stated range.
By their numbers in this assay, from the lowest: compounds 1, 2, 3 and 4 (each within the scatter of the next, the first and the last beyond it).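

Replacing methyl with 4-(trifluoromethyl)phenyl on the sulfonyl sulfur, where 1 heavy atom gives way to 10 heavy atoms and a six-membered aromatic ring, gives in this assay a number 7.5 percentage points higher from compound 3 to compound 4 (within the scatter). For the compounds shown here, this is the first measured change of the group at this position, and it shows that a much larger group can sit there while the number stays within the scatter, so the step cannot be read as a real gain. Nothing measured here explains the number for this group.

From the compounds shown here alone, whether any group on this sulfur can move the number beyond the scatter remains open. A plain phenyl or a 4-methoxyphenyl there would help separate the part played by the aromatic ring from that of the trifluoromethyl.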